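A Fluorine Added to a Cytotoxicity Series

The compounds below may be only part of what the source reports. "The series", "measured", "known", "first", "only" and "open" are said of these compounds alone.

Compound 1 `CN1Cc2ccc(OCc3ccccc3)cc2[C@@H](O)C1` is the parent of the series. In an ADME assay on Vero cells (Chlorocebus sabaeus) for cytotoxicity, read by sulforhodamine B assay, with a stated time of 72 h (a higher number here means a weaker inhibitor, a lower number a stronger inhibitor), compound 1 reaches only the assay limit of > 100000 nM, a limit rather than a number (the limit of > 100000 nM in this assay, at which 1 of the 2 values shown sits). Compound 2 `CN1Cc2ccc(OCc3ccc(Oc4ccccc4)cc3)cc2[C@@H](O)C1` carries a phenoxy group in place of a hydrogen on an aromatic carbon; in this assay compound 2 gives 3400 nM, the only actual number shown in this series. The step of an at least 29-fold lower number from compound 1 to compound 2 (1.46 log units; beyond the scatter) is large and well beyond the scatter.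

Compound 3 `CN1Cc2ccc(OCc3ccc(Oc4ccc(F)cc4)cc3)cc2[C@@H](O)C1` differs from compound 2 only by fluoro in place of hydrogen on an aromatic carbon. For the measured compounds named here, only one measured step bears on it, an at least 29-fold lower number from compound 1 to compound 2 (1.46 log units; beyond the scatter), and that step concerned a whole phenoxy group entering, not a single fluoro, so it offers little guidance for a change this small. Such a step is expected to stay within the scatter in this assay, with no clear direction. For compound 3 the estimated value in this assay is 3000 nM, with a range from 1000 nM to 10000 nM. The expected step of a 1.1-fold lower number from compound 2 to compound 3 (0.05 log units; within the scatter) is accordingly small.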

Compound 3, half-maximal inhibitory concentration: 5600 nM
Beside the measured number, compound 3's estimate is 1.9-fold (0.27 log units) below it; low and high end bracket the measured number.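

At this position, para to a large group on the six-membered aromatic ring of carbon only, fluoro in place of hydrogen gives a result in this assay that cannot be told apart from that of the unsubstituted phenoxy compound: a 1.6-fold higher number from compound 2 to compound 3 (0.22 log units; within the scatter). The change from phenoxy to 4-fluorophenoxy therefore leaves the earlier large step intact, and the group as a whole still stands well clear of the parent, with an at least 17-fold lower number from compound 1 to compound 3 (1.25 log units; beyond the scatter). Compound 1 remains a limit and not a number, so that step too has only one measured end: the limit of > 100000 nM in this assay, at which 1 of the 3 values shown sits.

The compounds shown leave open whether this place accepts other groups as readily as fluoro, for instance a chlorine, a methoxy group, a nitrile, an amine or a carboxylic acid, or whether fluoro is simply a change too small to register. They also leave open whether the large step belongs to the phenoxy group in particular, since a benzyl group or a simple phenyl group at the same carbon does not appear among them.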